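Amide variation on a shared core: toward an isoxazole amide

This account rests on a few compounds, and the source may have more. Where it says the series, first, only, none or still open, it means among the compounds named here.

Compound 1, `O=C(Nc1ccc(Cl)c(-c2nnc3c(Cl)cccn23)c1)c1ccc(Cl)cc1`, in a functional assay on T47D cells (Homo sapiens) for antiproliferative activity, read by MTT assay, with a stated time of 72 h (on this read-out lower numbers stand for stronger inhibition and higher numbers for weaker inhibition), sits at the assay's limit, > 100000 nM.
Compound 2, `O=C(Nc1ccc(Cl)c(-c2nnc3c(Cl)cccn23)c1)c1cccc(Cl)c1`, gives 30200 nM in this assay.
Compound 3, `O=C(Nc1ccc(Cl)c(-c2nnc3c(Cl)cccn23)c1)c1ccc(Cl)cc1Cl`, in this assay is again reported only as the limit, > 100000 nM.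

On the numbers shown, compound 3 stands at the weak end: its value is a limit, not a number, and the limit of > 100000 nM in this assay, at which 2 of the 3 values shown sit, places it alongside compound 1. The measured steps change only the chlorine pattern on the benzamide ring: an at least 3.3-fold lower number from compound 1 to compound 2 (0.51 log units; beyond the scatter), and an at least 3.3-fold higher number from compound 2 to compound 3 (0.51 log units; beyond the scatter). The step that the two limits leave unreadable from compound 1 to compound 3.

Compound 4, `O=C(Nc1ccc(Cl)c(-c2nnc3c(Cl)cccn23)c1)c1ccon1`, differs from compound 3 by 1,2-oxazol-3-yl in place of 2,4-dichlorophenyl on a carbonyl carbon. Going by the values given here, no measured step involves a five-membered heteroaryl in place of the chlorophenyl, so the measured steps bear only loosely on this change. Since the positional steps that do exist moved the number by at most a modest margin, compound 4 is expected to remain weak, with an at least 1.4-fold lower number from compound 3 to compound 4 (0.15 log units; that floor lies within the scatter) regarded as uncertain in direction. Compound 4 is estimated at 70000 nM, within 15000 nM to 200000 nM.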

Compound 4, half-maximal inhibitory concentration: > 100000 nM
Compound 4 was reported as a limit (the forecaster's own chance of this, stated with the estimate: 55%); at least 1.4-fold (0.15 log units) between middle value and limit.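

With the 1,2-oxazol-3-yl group on the carbonyl carbon, compound 4 in this assay gives only a limit, > 100000 nM and not a number, so replacing the chlorophenyl groups with this five-membered ring did not bring the compound off the limit. Going by these compounds alone, the one step that can be read is an at least 3.3-fold higher number from compound 2 to compound 4 (0.51 log units; beyond the scatter) and the steps that join two limits cannot be read. Among the groups shown at this place, only the 3-chlorophenyl of compound 2 gives a number, and the weak end now holds a group without chlorine as well as the chlorinated ones: the limit of > 100000 nM in this assay, at which 3 of the 4 values shown sit.

Open, from the compounds shown here alone, is whether another group on this carbonyl carbon, such as a 3-methoxyphenyl, a 3-aminophenyl or a saturated amine like morpholine, would give a lower number than compound 2. The limits of compound 1, compound 3 and compound 4 also give no order among these three.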